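A few compounds are considered here, and "the series" means these few. Any claim that something is new, unique, unknown or untested is made for them only; others in the source may bear on it.

In a functional assay on K562 cells (Homo sapiens) for cytotoxicity, read by trypan blue exclusion, with a stated time of 96 h (a higher number here means a weaker inhibitor, a lower number a stronger inhibitor), compound 1 `COc1cc(OC)c(/C=C/S(=O)(=O)Cc2ccc(OC)c([N+](=O)[O-])c2)c(OC)c1` gives 2500 nM. Going by the values given here, only one relative has a number so far: compound 2 `COc1ccc(CS(=O)(=O)/C=C/c2c(OC)cc(O)cc2OC)cc1[N+](=O)[O-]` gives 5000 nM. These two values lie within the scatter of each other, so no order can be read between them. Compound 3 `COc1cc(OC)c(/C=C/S(=O)(=O)Cc2ccc(F)c([N+](=O)[O-])c2)c(OC)c1` differs from compound 1 by a new change: fluoro in place of methoxy on an aromatic carbon. In words, this is fluoro in place of methoxy on an aromatic carbon, ortho to a nitro group. Among the compounds with values here, the only measured step, a 2.0-fold higher number from compound 1 to compound 2 (0.30 log units; within the scatter), is a different edit, with hydrogen in place of methyl on an oxygen on an aromatic ring. Within the data shown here, it therefore bears on compound 3 only weakly, and no measurement yet replaces this methoxy. Nothing points to a direction, so no shift beyond the scatter is expected in this assay, although the uncertainty is wide. The expected step is no change at the digits printed from compound 1 to compound 3 (within the scatter). For compound 3 the estimated value is 2500 nM, with an expected range from 700 nM to 9000 nM.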

Compound 3, half-maximal inhibitory concentration: 25000 nM
Compound 3: middle estimate off by 10-fold (1.00 log units), on the low side; the measured number lies above the stated range.
By their numbers in this assay, from the lowest: compounds 1 and 2 (each within the scatter of the next); then compound 3.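

In this assay, replacing the methoxy with fluoro on this aromatic carbon, ortho to a nitro group and para to a large group, gives a 10-fold higher number from compound 1 to compound 3 (1.00 log units; beyond the scatter), so compound 3 is a weaker inhibitor than compound 1. This is the first step shown that lies beyond the scatter, whereas the earlier edit at a different place, a 2.0-fold higher number from compound 1 to compound 2 (0.30 log units; within the scatter), stayed within it, and so the group on this carbon cannot be exchanged freely for fluoro without a visible loss. Nothing measured here explains why this exchange raises the number.

With only one replacement at this carbon, the compounds shown cannot tell whether the step reflects the loss of the methoxy or the arrival of the fluoro. On these data alone, an amine, a chloro group or a longer chain such as ethoxy on the same carbon could help separate those two readings, and it also remains open whether the same exchange would give a step of similar size on compound 2.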